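Moving the pyridine nitrogen in two related benzamide series

This account rests on a few compounds, and the source may have more. Where it says the series, first, only, none or still open, it means among the compounds named here.

Measured so far:
compound 1, `Nc1ccccc1NC(=O)c1ccc(CSC(=S)N2CCN(Cc3ccncc3)CC2)cc1`: 18.4%
compound 2, `Nc1ccccc1NC(=O)c1ccc(CSC(=S)N2CCN(Cc3cccnc3)CC2)cc1`: 37.7%
compound 3, `CN(Cc1ccncc1)C(=S)SCc1ccc(C(=O)Nc2ccccc2N)cc1`: 38.1%

In a functional assay on MGC-803 cells (Homo sapiens) for antiproliferative activity, read by CCK-8 assay, with a stated time of 72 h, tested at 2 uM (on this read-out lower numbers stand for a weaker effect and higher numbers for a stronger effect at the one concentration tested), compound 1 gives 18.4%. Compound 2 differs from it in one place only: pyridin-3-yl in place of pyridin-4-yl on a saturated chain carbon bound to an amine nitrogen in a ring. That single change produced a number 19.3 percentage points higher from compound 1 to compound 2 (beyond the scatter), a step beyond the scatter of this assay. Compound 3 is built on a different core; the difference between the cores of compound 1 and compound 3 is not broken down here. In this assay compound 3 gives 38.1%, a number within the scatter of that of compound 2, so the two cannot be ordered against each other.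

Compound 4, `CN(Cc1cccnc1)C(=S)SCc1ccc(C(=O)Nc2ccccc2N)cc1`, has not yet been measured. It differs from compound 3 by pyridin-3-yl in place of pyridin-4-yl on a saturated chain carbon bound to an amide-type nitrogen. Within the data shown here, this is the same kind of change as the one from compound 1 to compound 2, but the place is not the same word for word: in compound 1 the saturated chain carbon is bound to an amine nitrogen in a ring, whereas in compound 3 it is bound to an amide-type nitrogen. The expectation for compound 4 rests on one earlier step, a number 19.3 percentage points higher from compound 1 to compound 2 (beyond the scatter), made on a different core, and on the fact that compound 3 already gives 38.1%. A smaller gain is therefore expected, estimated as a number 9.9 percentage points higher from compound 3 to compound 4 (within the scatter). Compound 4 is expected to give about 48% in this assay, most likely between 30% and 66%.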

Compound 4, a percentage reported as inhibition, at one concentration (the size of the read-out at that concentration, not a potency): 45.9%
The estimate for compound 4 lay 2.1 percentage points above the measured number; measured number inside the range.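

Replacing pyridin-4-yl with pyridin-3-yl on the core of compound 3 gives, in this assay, a number 7.8 percentage points higher from compound 3 to compound 4 (within the scatter), so this step alone cannot be told apart from the ordinary variation between repeated measurements. Set beside the earlier step, the size of the effect of this change cannot be told apart on the two cores: the same change on two cores in this assay, a number 19.3 percentage points higher (beyond the scatter) from compound 1 to compound 2 and a number 7.8 percentage points higher (within the scatter) from compound 3 to compound 4, 11.5 percentage points apart, within the scatter of two such steps

Among these compounds, this does not show that the swap acts equally on both cores, nor that it acts differently, and it does not establish that pyridin-3-yl is a reliable improvement: only the step on the core of compound 1 stands clear of the scatter, and two pairs of compounds are a narrow basis for any rule about carrying a change from one core to another.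

The compounds shown hold only pyridin-3-yl and pyridin-4-yl, which leaves open what pyridin-2-yl or a plain phenyl group would give on either core. They also leave open whether the same picture would appear at other concentrations or in other cell lines, as every number here comes from one cell line at one concentration.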